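A few compounds are considered here, and "the series" means these few. Any claim that something is new, unique, unknown or untested is made for them only; others in the source may bear on it.

Measured in a functional assay on SK-MEL-28 cells (Homo sapiens) for inhibition, read by sulforhodamine B assay, with a stated time of 48 h; a lower number here means a stronger inhibitor of growth, a higher number a weaker inhibitor of growth:
- Compound 1 `CN1CCCN(CCNc2nccc(-c3c(-c4cccc(O)c4)nc4sccn34)n2)S1(=O)=O` gives 52000 nM
- Compound 2 `O=S(=O)(NCCCNc1nccc(-c2c(-c3cccc(O)c3)nc3sccn23)n1)c1cccc(F)c1` gives 6860 nM

Compound 2 has the lower of the two numbers, which makes it the stronger growth inhibitor so far. The next compound to be tested is compound 3 `O=S(=O)(NCCNc1nccc(-c2c(-c3cccc(O)c3)nc3sccn23)n1)c1ccc(F)cc1`. Its difference from compound 2 is ((4-fluorophenyl)sulfonyl)amino in place of (((3-fluorophenyl)sulfonyl)amino)methyl on a saturated chain carbon, two bonds along the chain from a nitrogen on an aromatic ring. In words, ((4-fluorophenyl)sulfonyl)amino stands in place of (((3-fluorophenyl)sulfonyl)amino)methyl on a saturated chain carbon, two bonds along the chain from a nitrogen on an aromatic ring.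

Among the measured compounds shown here, only one measured step bears on this, and only indirectly. That modest step, a 7.6-fold lower number from compound 1 to compound 2 (0.88 log units; beyond the scatter), brought in a group with a six-membered aromatic ring of carbon only, and the group entering compound 3 has such a ring too. For the measured compounds named here, no measured step isolates a change of the present kind, so the data give no direction for it. The expectation therefore stays close to compound 2 at 6860 nM. No change beyond the scatter is expected, and the estimate is a 1.2-fold higher number from compound 2 to compound 3 (0.07 log units; within the scatter). For compound 3 the expected value is 8000 nM, with an estimated range from 3000 nM to 25000 nM.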

Compound 3, concentration for total growth inhibition: 24000 nM
Beside the measured number, compound 3's estimate is 3.0-fold (0.48 log units) below it; measured number inside the range.
By their numbers in this assay, from the lowest: compound 2; then compound 3; then compound 1.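

In this assay, this position proves sensitive even to a change that keeps a fluorophenyl ring and a sulfonyl group in place: ((4-fluorophenyl)sulfonyl)amino in place of (((3-fluorophenyl)sulfonyl)amino)methyl gives a 3.5-fold higher number from compound 2 to compound 3 (0.54 log units; beyond the scatter). The group entering compound 3 still does better than the non-aromatic ring group of compound 1, with a 2.2-fold lower number from compound 1 to compound 3 (0.34 log units; beyond the scatter), so both groups with a carbon-only aromatic ring have lower numbers than compound 1, though the size of that advantage depends on which group is present. Nothing available explains why these groups differ in this way.

This one step changes two things at once: the fluorine moves from the 3- to the 4-position of the ring, and the methyl of the leaving group is gone, so the compounds shown cannot say which of the two matters. A compound carrying (((4-fluorophenyl)sulfonyl)amino)methyl would separate these two effects, while one with plain (phenylsulfonyl)amino would show whether the fluorine is needed at all.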